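The source may hold more compounds than are shown below. What is called first, only, known or untested is meant among the compounds shown, and "the series" means these compounds.

Working notes on the series. Compound 1 (`CN(C)CCCNc1nc2cc([N+](=O)[O-])ccc2nc1NCc1ccccc1`) gives 2.74 ug/mL in an ADME assay on HEK293 cells (Homo sapiens) for cytotoxicity, read by MTT assay, with a stated time of 24 h (a higher number here means a weaker inhibitor, a lower number a stronger inhibitor), and serves as the reference without a substituent on the benzyl ring. Compound 2 (`CN(C)CCCNc1nc2cc([N+](=O)[O-])ccc2nc1NCc1ccc(Br)cc1`) gives 9.63 ug/mL there, and compound 3 (`Cc1ccc(CNc2nc3ccc([N+](=O)[O-])cc3nc2NCCCN(C)C)cc1`) gives 15.8 ug/mL there too. Compound 3 shares the upper end of these three numbers with one neighbour: the measured steps are a 1.6-fold higher number from compound 2 to compound 3 (0.22 log units; within the scatter) on the one side and a 5.8-fold higher number from compound 1 to compound 3 (0.76 log units; beyond the scatter) on the other.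

The next member, compound 4 (`COc1ccc(CNc2nc3ccc([N+](=O)[O-])cc3nc2NCCCN(C)C)cc1`), carries methoxy in place of methyl on an aromatic carbon, para to a large group (methoxy in place of methyl on an aromatic carbon). Among the measured compounds shown here, no methoxy member has been measured, so the evidence is indirect. Adding a substituent at this place gave modest steps in both measured cases (a 3.5-fold higher number from compound 1 to compound 2 (0.55 log units; beyond the scatter) and a 5.8-fold higher number from compound 1 to compound 3 (0.76 log units; beyond the scatter)), while exchanging one substituent for the other stayed small (a 1.6-fold higher number from compound 2 to compound 3 (0.22 log units; within the scatter)). A further exchange at the same place is therefore expected to give no step beyond the scatter in this assay, with neither direction favoured. Expressed as a step, the estimate is a 1.2-fold lower number from compound 3 to compound 4 (0.08 log units; within the scatter) and is expected to stay within the scatter. The estimate for compound 4 is 13 ug/mL with an expected range from 5 ug/mL to 32 ug/mL overall.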

Compound 4, half-maximal inhibitory concentration: 38.6 ug/mL
Estimate against measurement, compound 4: 3.0-fold (0.47 log units) below, outside the stated range (above it).
By their numbers in this assay, from the lowest: compound 1; then compounds 2 and 3 (each within the scatter of the next); then compound 4.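

In this assay an exchange between substituents at this place is no longer always small: methoxy in place of methyl gives a step beyond the scatter (a 2.4-fold higher number from compound 3 to compound 4 (0.39 log units; beyond the scatter)), whereas methyl in place of bromo stayed within it (a 1.6-fold higher number from compound 2 to compound 3 (0.22 log units; within the scatter)). Methoxy also separates from bromo (a 4.0-fold higher number from compound 2 to compound 4 (0.60 log units; beyond the scatter)), and against the reference without a substituent on the benzyl ring it gives the only large step in the series so far (a 14-fold higher number from compound 1 to compound 4 (1.15 log units; beyond the scatter)), so at this place the number depends on which group is present and not only on whether a group is present. No measurement at hand bears on why methoxy separates from methyl and bromo.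

The compounds shown cannot tell whether the oxygen or the extra heavy atom of methoxy goes with the higher number; hydroxy, which keeps the oxygen, and ethyl, which keeps the heavy-atom count without oxygen, would pull the two apart. As far as these compounds go, how an amine or a carboxylic acid at this place would read in this assay also remains open.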